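Swapping the Triazole Aryl Group in an Inactive Series

This account rests on a few compounds, and the source may have more. Where it says the series, first, only, none or still open, it means among the compounds named here.

Of the compounds shown here, three sharing one spiro core have been tested in a functional assay on MCF7 cells (Homo sapiens) for antiproliferative activity, read by MTT assay, with a stated time of 48 h; on this read-out lower numbers stand for stronger inhibition and higher numbers for weaker inhibition. Compound 1 `N#CC1=C(N)Oc2c(c3nc4ccccc4nc3c3ccccc23)C12C(=O)N(Cc1cnnn1-c1ccc(F)cc1)c1ccccc12` carries a 4-fluorophenyl group on the triazole nitrogen. In this assay compound 1 reaches only the assay limit, > 50000 nM. Compound 2 `COc1ccc(-n2nncc2CN2C(=O)C3(C(C#N)=C(N)Oc4c3c3nc5ccccc5nc3c3ccccc43)c3ccccc32)cc1` bears a 4-methoxyphenyl group in the same place. In this assay compound 2 likewise gives only a limit, > 50000 nM. The change a step that the two limits leave unreadable from compound 1 to compound 2 therefore cannot be sized. Compound 3 `Cc1ccccc1-n1nncc1CN1C(=O)C2(C(C#N)=C(N)Oc3c(N)cc4nc5ccccc5nc4c32)c2ccccc21` has a 2-methylphenyl group on the triazole nitrogen and an additional amino group on the core. In this assay compound 3 also stops at the limit, > 50000 nM. All measured values thus sit at one point, the limit described by the limit of > 50000 nM in this assay, at which 3 of the 3 values shown sit, so compound 3 stands no differently from the other two as far as the numbers show.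

Compound 4 `N#CC1=C(N)Oc2c(N)cc3nc4ccccc4nc3c2C12C(=O)N(Cc1cnnn1-c1cccc(Br)c1)c1ccccc12` differs from compound 3 in one place: 3-bromophenyl in place of 2-methylphenyl on an aromatic nitrogen. Among the compounds with values here, no measured step bears on this change with a readable size, because every step so far is hidden by the limit of > 50000 nM in this assay, at which 3 of the 3 values shown sit. The step that the limit leaves unreadable from compound 3 to compound 4 is therefore expected to stay within the scatter, with another limit the most likely outcome. Compound 4 is estimated at 60000 nM, within 20000 nM to 200000 nM.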

Compound 4, half-maximal inhibitory concentration: > 50000 nM
Compound 4 gave a limit, no number (the forecaster's own chance of this, stated with the estimate: 80%); the middle value lies beyond the limit too.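

Compound 3 and compound 4 both stop at the assay limit, so the step of 3-bromophenyl in place of 2-methylphenyl cannot be read: the limit of > 50000 nM in this assay, at which 4 of the 4 values shown sit.

The compounds shown leave open whether any aryl group on the triazole, or any change to the shared core, would give a measurable value in this assay.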